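Lipophilicity notes: a pyrazole swap in the fused-core series

The compounds below may be only part of what the source reports. "The series", "measured", "known", "first", "only" and "open" are said of these compounds alone.

Measured so far in a physicochemical assay for lipophilicity, using the shake flask method, in phosphate buffer, measured as octanol-water partition, with a stated time of 30 min, at pH 7.4; on this read-out higher numbers stand for higher lipophilicity and lower numbers for lower lipophilicity:
compound 1 `CNC(=O)c1ccc(-c2cnc(NCc3c(F)ccc4c3CCO4)c3cn[nH]c(=O)c23)c(C)n1` gives 2.9
compound 2 `Cc1nc(CN(C)C)ccc1-c1cnc(NCc2c(F)ccc3c2CCO3)c2cn[nH]c(=O)c12` gives 2
compound 3 `CNC(=O)c1ncc(-c2cnc(NCc3c(F)ccc4c3CCO4)c3cn[nH]c(=O)c23)n1C` gives 2.5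

Compound 3 sits second highest of the three numbers; its nearest neighbour is compound 1 at a number 0.40 log units lower from compound 1 to compound 3 (beyond the scatter), and its furthest is compound 2 at a number 0.50 log units higher from compound 2 to compound 3 (beyond the scatter).

The next compound, compound 4 `Cn1nccc1-c1cnc(NCc2c(F)ccc3c2CCO3)c2cn[nH]c(=O)c12`, differs from compound 3 in one place: 1-methyl-1H-pyrazol-5-yl in place of 1-methyl-2-(methylcarbamoyl)-1H-imidazol-5-yl on an aromatic carbon.

Going by the values given here, of the measured steps, the one from compound 1 to compound 2 removes the methylcarbamoyl group and gives a number 0.90 log units lower from compound 1 to compound 2 (beyond the scatter), though it puts a (dimethylamino)methyl in its stead rather than a bare ring. The steps of a number 0.40 log units lower from compound 1 to compound 3 (beyond the scatter) and a number 0.50 log units higher from compound 2 to compound 3 (beyond the scatter) swap the whole ring. Among the compounds with values here, no measured step removes the methylcarbamoyl without a replacement, and none compares a 1-methyl-1H-pyrazol-5-yl with anything. Loss of the methylcarbamoyl, with its one hydrogen-bond donor and extra acceptor, is expected to move this assay upward by a modest amount, with wide uncertainty.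

For compound 4 the expected value is 3.2, within 2.6 to 3.8, which corresponds to an expected step of a number 0.70 log units higher from compound 3 to compound 4 (beyond the scatter).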

Compound 4, distribution coefficient: 2.6
For compound 4 the middle estimate is 0.60 log units above the measured one, and the stated range covers the measured number.
By their numbers in this assay, from the lowest: compound 2; then compounds 3, 4 and 1 (each within the scatter of the next, the first and the last beyond it).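

In this assay, replacing 1-methyl-2-(methylcarbamoyl)-1H-imidazol-5-yl, with 10 heavy atoms, by 1-methyl-1H-pyrazol-5-yl, with 6, gives a number 0.10 log units higher from compound 3 to compound 4 (within the scatter), so at this aromatic carbon the ring without the methylcarbamoyl reads level with the ring that carries it. Going by these compounds alone, the swap from 2-methyl-6-(methylcarbamoyl)pyridin-3-yl gives a number 0.30 log units lower from compound 1 to compound 4 (within the scatter), whereas the swap from 6-((dimethylamino)methyl)-2-methylpyridin-3-yl gives a number 0.60 log units higher from compound 2 to compound 4 (beyond the scatter), so of the three rings compared with the pyrazole, only the one bearing (dimethylamino)methyl stands apart from it. Nothing available accounts for these readings.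

The compounds shown do not separate the contribution of the methylcarbamoyl from that of the ring carrying it: a 1-methylimidazol-5-yl without the amide and a pyrazole with it would be needed. As far as these compounds go, how a carboxylic acid or a primary amine on the pyrazole would read also stays open.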